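Aryl change on the hydrazone of the triazole glycoside

A few compounds are considered here, and "the series" means these few. Any claim that something is new, unique, unknown or untested is made for them only; others in the source may bear on it.

Three compounds have numbers: compound 1 `CC1(C)O[C@H]2O[C@H](Cn3cc(CN4C(=O)/C(=N\Nc5cccc(Cl)c5)c5ccccc54)nn3)[C@H](O)[C@H]2O1`, compound 2 `O=C1/C(=N\Nc2ccc(Br)cc2)c2ccccc2N1Cc1cn(O[C@@H]2O[C@H](CO)[C@H](O)[C@H](O)[C@H]2O)nn1` and compound 3 `N#Cc1ccc(N/N=C2\C(=O)N(Cc3cn(O[C@@H]4O[C@H](CO)[C@H](O)[C@H](O)[C@H]4O)nn3)c3ccccc32)cc1`. In an ADME assay on Vero cells (Chlorocebus sabaeus) for cytotoxicity, read by fluorescence and resazurin assay, with a stated time of 3 days (a higher number here means that more compound is tolerated, a lower number that less compound is tolerated), compound 1 gives 70000 nM, compound 2 gives 91500 nM, and compound 3 gives 93700 nM. Compound 3 holds the highest of the three numbers, yet its gaps to compound 2 and to compound 1 both lie within the scatter, so no order among them is claimed. Among the measured compounds shown here, the one single-point step, a 1.0-fold higher number from compound 2 to compound 3 (0.01 log units; within the scatter), is flat. Compound 4 is `O=C1/C(=N\Nc2cccc(Cl)c2)c2ccccc2N1Cc1cn(O[C@@H]2O[C@H](CO)[C@H](O)[C@H](O)[C@H]2O)nn1`; it differs from compound 3 by 3-chlorophenyl in place of 4-cyanophenyl on an amine nitrogen. For the measured compounds named here, no measured step covers this exchange; the flat step a 1.0-fold higher number from compound 2 to compound 3 (0.01 log units; within the scatter) on the same ring, and compound 1 carrying the same 3-chlorophenyl at 70000 nM, lead to the expectation of no step beyond the scatter. Compound 4 is therefore expected near 80000 nM, with a range of 40000 nM to 160000 nM, a step of a 1.2-fold lower number from compound 3 to compound 4 (0.07 log units; within the scatter).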

Compound 4, half-maximal cytotoxic concentration: 84500 nM
Compound 4: the middle estimate sits 1.1-fold (0.02 log units) below what was measured, within the range that was stated.
By their numbers in this assay, from the lowest: compounds 1, 4, 2 and 3 (each within the scatter of the next).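

In this assay, 3-chlorophenyl on the amine nitrogen is flat against both 4-cyanophenyl (a 1.1-fold lower number from compound 3 to compound 4 (0.04 log units; within the scatter)) and 4-bromophenyl (a 1.1-fold lower number from compound 2 to compound 4 (0.03 log units; within the scatter)), so all three aryl groups at this position lie within the scatter. With 3-chlorophenyl held constant, exchanging the group on the aromatic nitrogen is flat as well (a 1.2-fold higher number from compound 1 to compound 4 (0.08 log units; within the scatter)). Nothing measured here bears on why these steps are flat.

Going by these compounds, it remains open whether a carboxylic acid or an amine on the phenyl ring would give a step beyond the scatter. The same question stands for a longer alkyl chain in place of the phenyl ring.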